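A Fluoro for a Methyl on the Amide Aryl Group

The source may report more compounds than this note shows. Statements on the series, on what has been measured and on what is new or still open speak of the compounds shown alone.

Compound 1 `Cc1ccc(N2C(=O)COc3ccc(-c4cnc5ccccc5c4)cc32)cc1` carries a 4-methylphenyl on the amide nitrogen of the shared core. In a functional assay on MCF7 cells (Homo sapiens) for antiproliferative activity, read by MTT assay, with a stated time of 72 h (a lower number here means a stronger inhibitor, a higher number a weaker inhibitor), compound 1 gives > 40000 nM, and that figure is a limit of the assay rather than a measured number. Two further compounds keep the core but carry a different, sulfonamide-bearing aryl group at the other end: compound 2 `O=C1COc2ccc(-c3cnc(Cl)c(NS(=O)(=O)c4ccc(F)cc4)c3)cc2N1c1ccc(Cl)cc1` gives 32800 nM in this assay, and compound 3 `Cc1ccc(N2C(=O)COc3ccc(-c4cnc(Cl)c(NS(=O)(=O)c5ccc(F)cc5)c4)cc32)cc1` gives 32600 nM. The step of a 1.0-fold lower number from compound 2 to compound 3 (0.00 log units; within the scatter) therefore shows that exchanging chloro for methyl on the amide aryl group leaves the read-out essentially unchanged.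

Compound 4 `O=C1COc2ccc(-c3cnc4ccccc4c3)cc2N1c1ccc(F)cc1` differs from compound 1 by fluoro in place of methyl on an aromatic carbon. Within the data shown here, no measured step involves fluoro, so the only guide is the chloro-to-methyl exchange at the same position in the pair above, which stayed within the scatter. On that basis the swap of methyl for fluoro in compound 4 is expected to bring no step beyond the scatter, so that a step that the limit leaves unreadable from compound 1 to compound 4 is estimated to be flat. Since compound 1 itself sits at the limit of > 40000 nM in this assay, at which 1 of the 3 values shown sits, compound 4 is most likely expected to return a limit as well, with an estimated value of 45000 nM and a plausible range from 15000 nM to 150000 nM.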

Compound 4, half-maximal inhibitory concentration: > 40000 nM
Compound 4: only a limit was reported; the forecaster's own chance of this, stated with the estimate: 70%; the middle value does not contradict the limit.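

Compound 4 gives > 40000 nM in this assay, which is a limit of the assay and not a number. Compound 1 also stands at a limit, so no step can be read between compound 1 and compound 4: the limit of > 40000 nM in this assay, at which 2 of the 4 values shown sit.

The compounds shown leave open how fluoro and methyl on the amide aryl group compare.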